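Restoring a Carbonyl: What Compound 4 Is Expected to Show

The source may hold more compounds than are shown below. What is called first, only, known or untested is meant among the compounds shown, and "the series" means these compounds.

Of the compounds shown here, three built on one shared core have been tested in a functional assay on the whole organism (strain albino) for inhibition, with Rattus norvegicus as the target, read by paw edema, with stated times of 1 h and 2 h, at a dose of 20 mmol/kg by the intraperitoneal route; a higher number here means more inhibition at the dose given (going by the name of the read-out), a lower number less inhibition. Compound 1 `N#CC1=C(NCC(=O)N2CCOCC2)N(c2ccccc2)C(=O)N2CCCCC(N3CCCC3)C12` gives 69.8%. Compound 2 `COc1ccc(N/C=N/C2=C(C#N)C3C(N4CCCC4)CCCCN3C(=O)N2c2ccccc2)cc1` gives 37.2%, and compound 3 `N#CC1=C(NCN2CCCCC2)N(c2ccccc2)C(=O)N2CCCCC(N3CCCC3)C12` gives 36.9%. Compound 3 stands lowest of the three numbers shown, though within the scatter of compound 2 and far beneath compound 1. Compound 4 `N#CC1=C(NCC(=O)N2CCCCC2)N(c2ccccc2)C(=O)N2CCCCC(N3CCCC3)C12` differs from compound 3 by (piperidin-1-yl)carbonyl in place of piperidin-1-yl on a saturated chain carbon bound to an amine nitrogen. Among the measured compounds shown here, one measured step bears on this: removing a carbonyl in a number 32.9 percentage points lower from compound 1 to compound 3 (beyond the scatter) ran the opposite way, so restoring a carbonyl is expected to raise the number well beyond the scatter, as a number 25.1 percentage points higher from compound 3 to compound 4 (beyond the scatter). Compound 4 is therefore estimated at 62%, within a range from 45% to 78%.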

Compound 4, a percentage reported as inhibition, in the whole organism at one dose (the size of the read-out at that dose, not a potency): 46.1%
Beside the measured number, compound 4's estimate is 15.9 percentage points above it, and the stated range covers the measured number.
By their numbers in this assay, from the lowest: compounds 3, 2 and 4 (each within the scatter of the next); then compound 1.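

In this assay, the carbonyl on the saturated chain carbon bound to an amine nitrogen gives a number 9.2 percentage points higher from compound 3 to compound 4 (within the scatter) when the ring on the chain is piperidin-1-yl, so here it has no readable effect on its own. The ring on the carbonyl carbon does count: piperidin-1-yl in place of morpholin-4-yl gives a number 23.7 percentage points lower from compound 1 to compound 4 (beyond the scatter) and accounts for much of the gap once read as the carbonyl's alone. Among the compounds shown here, the group on the double-bonded ring carbon in compound 4 also gives a number 8.9 percentage points higher from compound 2 to compound 4 (within the scatter) against the one in compound 2, so these two cannot be told apart.

On these data alone, it remains open how another amine on that carbonyl, such as pyrrolidin-1-yl or dimethylamino, would read. Nothing available explains the difference between the two rings.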